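The source may hold more compounds than are shown below. What is called first, only, known or untested is meant among the compounds shown, and "the series" means these compounds.

Compound 2 `Cc1ccc(S(=O)(=O)N(Cc2cn(Cc3cccc(F)c3F)nn2)Cc2cn(S(=O)(=O)c3ccc(C)cc3)c3ccccc23)cc1` stands highest of the two compounds measured in a functional assay on 3T3-L1 cells (Mus musculus) for inhibition, with a stated time of 20 min, tested at 20 uM (a higher number here means more inhibition at the concentration tested (going by the name of the read-out), a lower number less inhibition), where compound 2 gives 71.5%. For the measured compounds named here, the only other measured compound, compound 1 `COc1ccc(Cn2cc(CN(Cc3cn(S(=O)(=O)c4ccc(C)cc4)c4ccccc34)S(=O)(=O)c3ccc(C)cc3)nn2)c(OC)c1OC`, gives -18% in this assay, and the step of a number 89.5 percentage points higher from compound 1 to compound 2 (beyond the scatter) shows that the group on the saturated chain carbon bound to an aromatic nitrogen matters greatly. Compound 3 `Cc1ccc(S(=O)(=O)N(Cc2cn(Cc3ccccc3)nn2)Cc2cn(S(=O)(=O)c3ccc(C)cc3)c3ccccc23)cc1` differs from compound 2 at that same place: phenyl in place of 2,3-difluorophenyl on a saturated chain carbon bound to an aromatic nitrogen. Going by the values given here, only that one large step bears on the change, and it swapped a whole trimethoxyphenyl ring, while here only the fluorines leave, so a smaller downward step is expected. Compound 3 is expected to give 50%, between 20% and 78%, an expected step of a number 21.5 percentage points lower from compound 2 to compound 3 (beyond the scatter).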

Compound 3, a percentage reported as inhibition, at one concentration (the size of the read-out at that concentration, not a potency): 3.4%
Estimate against measurement, compound 3: 46.6 percentage points above; measured number outside the range, below it.
By their numbers in this assay, from the lowest: compound 1; then compound 3; then compound 2.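

In this assay, the change from 2,3-difluorobenzyl to benzyl gives a number 68.1 percentage points lower from compound 2 to compound 3 (beyond the scatter), so at this place the inhibition depends on the two fluorines and not merely on having an unsubstituted phenyl ring there. Replacing 2,3,4-trimethoxyphenyl with phenyl gives only a number 21.4 percentage points higher from compound 1 to compound 3 (beyond the scatter), so removing the methoxy groups does not by itself recover the level of compound 2. Nothing available explains these differences. Still open, going by these compounds, is whether a single fluorine would keep the inhibition, and how a chlorine, a pyridine ring or a longer chain would behave here.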